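Swapping the aryl amide on a thiourea scaffold

The source may hold more compounds than are shown below. What is called first, only, known or untested is meant among the compounds shown, and "the series" means these compounds.

Compound 1, `Cc1ccc(C(=O)Nc2sc3c(c2C(N)=O)CCN(Cc2c(Cl)cccc2Cl)C3)cc1`: in a functional assay on HeLa cells (Homo sapiens) for antiproliferative activity, with a stated time of 24 h (on this read-out lower numbers stand for stronger inhibition and higher numbers for weaker inhibition), compound 1 gives 47400 nM.
Compound 2, `NC(=O)c1c(NC(=O)c2ccccc2)sc2c1CCN(C(=S)Nc1ccccc1Cl)C2`: compound 2 reaches only the assay limit of > 50000 nM.
Compound 3, `COc1ccccc1C(=O)Nc1sc2c(c1C(N)=O)CCN(C(=S)Nc1ccccc1Cl)C2`: compound 3 likewise reaches only the assay limit of > 50000 nM.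

Compound 3 therefore sits at the limit rather than at a number, as the limit of > 50000 nM in this assay, at which 2 of the 3 values shown sit, shows. Within the data shown here, the one step that joins two measured compounds, a step that the two limits leave unreadable from compound 2 to compound 3, is unreadable. Compound 4, `Cc1ccc(C(=O)Nc2sc3c(c2C(N)=O)CCN(C(=S)Nc2ccccc2Cl)C3)cc1`, differs from compound 3 by 4-methylphenyl in place of 2-methoxyphenyl on a carbonyl carbon. Among the measured compounds shown here, no measured step covers this change. Compound 1 carries the same 4-methylphenyl group and gives 47400 nM in this assay. On that basis compound 4 is expected to stay near the limit, an estimated step of a number no higher from compound 3 to compound 4 (the limit leaves the size open). The estimate for compound 4 is 50000 nM, between 20000 nM and 150000 nM.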

Compound 4, half-maximal inhibitory concentration: 26300 nM
Beside the measured number, compound 4's estimate is 1.9-fold (0.28 log units) above it, and the stated range covers the measured number.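

With 4-methylphenyl on the carbonyl carbon, compound 4 gives a number in this assay, whereas the other two compounds with the same thiourea group stop at a limit: the limit of > 50000 nM in this assay, at which 2 of the 4 values shown sit.

As far as these compounds go, the two steps to it are floors only, an at least 1.9-fold lower number from compound 3 to compound 4 (0.27 log units; that floor lies within the scatter) and an at least 1.9-fold lower number from compound 2 to compound 4 (0.27 log units; that floor lies within the scatter), so the true size of this change remains unknown. With the 4-methylphenyl amide held constant, swapping the group on the ring nitrogen gives a 1.8-fold lower number from compound 1 to compound 4 (0.26 log units; within the scatter).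

The compounds shown leave open how an amine or a carboxylic acid in place of the methyl of compound 4 would read in this assay.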